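The compounds below may be only part of what the source reports. "The series", "measured", "known", "first", "only" and "open" are said of these compounds alone.

In a functional assay on MCF7 cells (Homo sapiens) for inhibition, read by MTT assay, with a stated time of 48 h (a higher number here means a weaker inhibitor, a lower number a stronger inhibitor), compound 1 `COc1ccc(-c2ccnc3c2c(-c2ccccc2)nn3-c2ccccc2)cc1` gives 28700 nM. Compound 2 `O=C(C=CNc1cc(-c2ccccc2)nn1-c1ccccc1)c1cccs1`, which has a different structure, gives 15400 nM in this assay. These two values lie within the usual scatter of each other, so the numbers do not separate compound 2 from compound 1.

Compound 3 `O=C(C=CNc1cc(-c2ccccc2)nn1-c1ccccc1)c1ccc(F)cc1` keeps all of compound 2 except for one group: 4-fluorophenyl in place of thiophen-2-yl on a carbonyl carbon. Here, 4-fluorophenyl takes the place of thiophen-2-yl on a carbonyl carbon, and the rest of the molecule stays the same. Among the measured compounds shown here, no measured pair of compounds shows what this swap does. For the measured compounds named here, the only guide is compound 2 at 15400 nM, so no step beyond the scatter is expected in this assay, in either direction. The expected change is a 1.1-fold lower number from compound 2 to compound 3 (0.04 log units; within the scatter). For compound 3, the estimated value is 14000 nM, with an expected range of 5000 nM to 38000 nM.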

Compound 3, half-maximal inhibitory concentration: 9180 nM
Compound 3: middle estimate off by 1.5-fold (0.18 log units), on the high side; the range from low to high includes it.
By their numbers in this assay, from the lowest: compounds 3, 2 and 1 (each within the scatter of the next, the first and the last beyond it).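

On a carbonyl carbon whose other neighbour is a double-bonded chain carbon, putting 4-fluorophenyl in place of thiophen-2-yl gives a 1.7-fold lower number from compound 2 to compound 3 (0.22 log units; within the scatter) in this assay. Among the compounds shown here, this is the first direct look at this position, and it shows that a six-membered aromatic ring of carbon only and a five-membered aromatic ring with one hetero atom cannot be told apart here by their numbers. Nothing available explains this result.

From the compounds shown here alone, in this swap, the ring and the fluorine enter together, so the share of each stays open. Going by these compounds, it also remains open whether plain phenyl, an aminophenyl ring or a short chain such as methyl on the same carbonyl carbon would give a step beyond the scatter.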